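The source may report more compounds than this note shows. Statements on the series, on what has been measured and on what is new or still open speak of the compounds shown alone.

Compound 2 `CC(C)n1c(=O)n(C(=O)NCCN2CCN(C)CC2)c2ccccc21` carries the shared core with an isopropyl on an aromatic nitrogen. In a functional assay for antagonist activity at 5-hydroxytryptamine receptor 4 (Cavia porcellus) (on this read-out higher numbers stand for higher potency (the scale is a negative logarithm) and lower numbers for lower potency), compound 2 gives < 6, which is a limit of the assay and not a number. Compound 1 `CN1CCN(CCNC(=O)n2c(=O)n(Cc3ccccc3)c3ccccc32)CC1` in this assay gives < 6, also a limit. Compound 3 `CN1CCN(CCNC(=O)n2c(=O)n(C)c3ccccc32)CC1` in this assay gives < 6, again a limit. Compound 4 `CC(C)n1c(=O)n(C(=O)NCCCN2CCN(C)CC2)c2ccccc21` differs from compound 2 by (4-methylpiperazin-1-yl)methyl in place of 4-methylpiperazin-1-yl on a saturated chain carbon, two bonds along the chain from an amide-type nitrogen. The measured steps a step that the two limits leave unreadable from compound 1 to compound 2, a step that the two limits leave unreadable from compound 1 to compound 3 and a step that the two limits leave unreadable from compound 2 to compound 3 cannot be sized because of the limit of < 6 in this assay, at which 3 of the 3 values shown sit, and none of them touches the chain. No basis for a direction exists, so the step from compound 2 to compound 4 is expected at a number no lower from compound 2 to compound 4 (the limit leaves the size open). Compound 4 is estimated at 6, with a range from 5.3 to 6.9.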

Compound 4, negative logarithm of the antagonist equilibrium constant: < 6
Compound 4 ended at the assay's limit; the forecaster's own chance of this, stated with the estimate: 60%; the middle value lies on the limit itself.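

No step can be read from compound 2 to compound 4, because both values are limits and not numbers: the limit of < 6 in this assay, at which 4 of the 4 values shown sit.

As far as these compounds go, whether (4-methylpiperazin-1-yl)methyl in place of 4-methylpiperazin-1-yl, or any change of the group on the aromatic nitrogen, alters potency remains open.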